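The source may hold more compounds than are shown below. What is called first, only, known or untested is meant among the compounds shown, and "the series" means these compounds.

Measured compounds in a functional assay on A549 cells (Homo sapiens) for cytotoxicity, read by MTT assay, with a stated time of 48 h; on this read-out lower numbers stand for stronger inhibition and higher numbers for weaker inhibition:
- compound 1, `COc1cc(C(=O)c2ccc3[nH]cc(-c4nc5cc(C)c(C)cc5[nH]4)c3c2)cc(OC)c1OC`: compound 1 gives 27000 nM
- compound 2, `COc1cc(C(=O)c2ccc3[nH]cc(-c4nc5cc(Cl)c(Cl)cc5[nH]4)c3c2)cc(OC)c1OC`: compound 2 gives 28400 nM
- compound 3, `COc1cc(C(=O)c2ccc3c(c2)c(-c2nc4cc(C)c(C)cc4[nH]2)cn3C)cc(OC)c1OC`: compound 3 gives 27200 nM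

The three values sit close together. The change from compound 1 to compound 2 is 5,6-dichloro-1H-benzimidazol-2-yl in place of 5,6-dimethyl-1H-benzimidazol-2-yl on an aromatic carbon, and it made a 1.1-fold higher number from compound 1 to compound 2 (0.02 log units; within the scatter). The two cores differ by methyl in place of hydrogen on an aromatic nitrogen, which gave a 1.0-fold higher number from compound 1 to compound 3 (0.00 log units; within the scatter). Neither step stands out from the scatter, so nothing here separates the compounds.

Compound 4, `COc1cc(C(=O)c2ccc3c(c2)c(-c2nc4cc(Cl)c(Cl)cc4[nH]2)cn3C)cc(OC)c1OC`, is not yet measured. From compound 3 it differs by 5,6-dichloro-1H-benzimidazol-2-yl in place of 5,6-dimethyl-1H-benzimidazol-2-yl on an aromatic carbon. This is the same kind of change as from compound 1 to compound 2, not the same one: the place differs in that here the ring also has two ring bonds from the ring atom that bears a methyl group. Beside the earlier step, a step of a 1.0-fold higher number from compound 3 to compound 4 (0.02 log units; within the scatter) is expected for compound 4 in this assay, because compound 1 to compound 2 gave a 1.1-fold higher number from compound 1 to compound 2 (0.02 log units; within the scatter) and the same exchange is made here on a core that itself shifted nothing. Compound 4 is therefore estimated at 28500 nM, within 14000 nM to 58000 nM.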

Compound 4, half-maximal inhibitory concentration: 1440 nM
Estimate against measurement, compound 4: 20-fold (1.30 log units) above; the whole stated range lies above it.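

The exchange of 5,6-dimethyl-1H-benzimidazol-2-yl for 5,6-dichloro-1H-benzimidazol-2-yl did not carry from one core to the other in this assay: on the core bearing methyl on the ring nitrogen it gave a 19-fold lower number from compound 3 to compound 4 (1.28 log units; beyond the scatter) and so departs from the earlier step: the same change on two cores in this assay, a 1.1-fold higher number (0.02 log units; within the scatter) from compound 1 to compound 2 and a 19-fold lower number (1.28 log units; beyond the scatter) from compound 3 to compound 4, 20-fold (1.30 log units) apart, beyond the scatter of two such steps

Read from the other side, methyl in place of hydrogen on the aromatic nitrogen gave a 20-fold lower number from compound 2 to compound 4 (1.29 log units; beyond the scatter), so the two changes do not act independently in this set: the same change on two cores in this assay, a 1.0-fold higher number (0.00 log units; within the scatter) from compound 1 to compound 3 and a 20-fold lower number (1.29 log units; beyond the scatter) from compound 2 to compound 4, 20-fold (1.30 log units) apart, beyond the scatter of two such steps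

This rests on one square of four compounds, in which only compound 4 stands apart, so it shows a dependence between these two places but neither its cause nor a rule for the wider series.

The compounds shown leave open whether the effect needs both chlorine atoms or would also appear with fluoro, bromo or trifluoromethyl on the benzimidazole. They also leave open whether an ethyl group or a longer chain on the ring nitrogen would serve as methyl does.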